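This account rests on a few compounds, and the source may have more. Where it says the series, first, only, none or still open, it means among the compounds named here.

In a functional assay on A2780 cells (Homo sapiens) for inhibition, read by sulforhodamine B assay (a lower number here means a stronger inhibitor of growth, a higher number a weaker inhibitor of growth), compound 1 (`c1ccc(-c2ccc(-c3ccc(-c4nc5ccccc5[nH]4)cc3)cc2)cc1`) gives 32100 nM. Compound 2 (`Oc1ccc(-c2ccc(-c3ccc(-c4nc5ccccc5[nH]4)cc3)cc2)cc1`) gives 36000 nM, and compound 3 (`Clc1cccc(-c2ccc(-c3ccc(-c4nc5ccccc5[nH]4)cc3)cc2)c1`) gives 31100 nM. Compound 1 therefore stands level with both of its neighbours, as all three numbers lie within the usual scatter of this kind of measurement.

Compound 4 (`Oc1cccc2[nH]c(-c3ccc(-c4ccc(-c5ccccc5)cc4)cc3)nc12`) changes compound 1 in a single place: hydroxy in place of hydrogen on an aromatic carbon. This is hydroxy in place of hydrogen on an aromatic carbon, on a ring that is part of a fused system of two rings. The closest guide is compound 2, which carries a hydroxy elsewhere in the molecule, with a 1.1-fold higher number from compound 1 to compound 2 (0.05 log units; within the scatter). Compound 3 adds a chloro group, with a 1.0-fold lower number from compound 1 to compound 3 (0.01 log units; within the scatter), and the remaining comparison shows a 1.2-fold lower number from compound 2 to compound 3 (0.06 log units; within the scatter).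

Among the measured compounds shown here, none of the measured compounds has a group added on the fused rings, so this guide is only partial, and the range must stay wide. No step beyond the scatter is expected, and the estimated step is a 1.1-fold lower number from compound 1 to compound 4 (0.03 log units; within the scatter). For compound 4, the expected value is 30000 nM, within an estimated range of 11000 nM to 65000 nM.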

Compound 4, concentration for 50% growth inhibition: 41000 nM
The estimate for compound 4 lay 1.4-fold (0.14 log units) below the measured number; measured number inside the range.
By their numbers in this assay, from the lowest: compounds 3, 1, 2 and 4 (each within the scatter of the next).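

In this assay the step is a 1.3-fold higher number from compound 1 to compound 4 (0.11 log units; within the scatter) when hydroxy replaces hydrogen on an aromatic carbon of the fused system of two rings. Among the compounds shown here, this is the first look at a group on those fused rings, and at this position the exchange leaves compound 4 within the scatter of compound 1, as a hydroxy elsewhere in the molecule did for compound 2. No measurement shown gives a reason for this result.

From the compounds shown here alone, whether another group at this position, such as an amine, a methoxy or a carboxylic acid, would move the number beyond the scatter remains open. Also open, going by these compounds, is whether hydroxy on the other aromatic carbons of this six-membered ring would behave as it does in compound 4.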